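Removing the ethoxycarbonyl from compound 3

This account rests on a few compounds, and the source may have more. Where it says the series, first, only, none or still open, it means among the compounds named here.

Compound 1 `COc1cc(C2OC(c3ccc(N(C)C)cc3)=NN2C(C)=O)cc(OC)c1OC` gives 0.044 uM
Compound 2 `COc1cc(C2OC(c3ccc(N(C)C)cc3)=NN2C=O)cc(OC)c1OC` gives 0.12 uM
Compound 3 `CCOC(=O)C(=O)N1N=C(c2ccc(N(C)C)cc2)OC1c1cc(OC)c(OC)c(OC)c1` gives 33 uM

In a functional assay on NCI-H460 cells (Homo sapiens) (on this read-out lower numbers stand for an effect already at smaller amounts and higher numbers for an effect only at larger amounts of compound), compound 3 has the highest number of the three, at 33 uM, and compound 2 is its nearest neighbour, though still far lower. Compound 4 `COC(=O)N1N=C(c2ccc(N(C)C)cc2)OC1c1cc(OC)c(OC)c(OC)c1` puts methoxy in place of ethoxycarbonyl on a carbonyl carbon. All three measured steps bear on this place. Ethoxycarbonyl on that carbonyl carbon came with a 750-fold higher number from compound 1 to compound 3 (2.88 log units; beyond the scatter) and with a 280-fold higher number from compound 2 to compound 3 (2.44 log units; beyond the scatter) and both of these are large. Hydrogen in place of methyl gave only a 2.7-fold higher number from compound 1 to compound 2 (0.44 log units; beyond the scatter) and that step is modest. Methoxy itself has not been measured here, so the size remains uncertain, but compound 4 is expected to fall back toward the low numbers of the two compounds without ethoxycarbonyl, probably not quite as far. The expected change is a 66-fold lower number from compound 3 to compound 4 (1.82 log units; beyond the scatter) and this would be a large step toward a lower number. Compound 4 is estimated at 0.5 uM with an expected range from 0.05 uM to 8 uM in this read-out.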

Compound 4, concentration for half-maximal effect: 106 uM
Beside the measured number, compound 4's estimate is 210-fold (2.33 log units) below it; measured number above the stated range.
By their numbers in this assay, from the lowest: compound 1; then compound 2; then compound 3; then compound 4.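

In this assay, the smaller group on the carbonyl carbon did not bring the number back down: methoxy in place of ethoxycarbonyl gave a 3.2-fold higher number from compound 3 to compound 4 (0.51 log units; beyond the scatter), so the high numbers at this position are not confined to ethoxycarbonyl. Methoxy instead stands with ethoxycarbonyl and far from hydrogen and methyl, with an 880-fold higher number from compound 2 to compound 4 (2.95 log units; beyond the scatter) and a 2400-fold higher number from compound 1 to compound 4 (3.38 log units; beyond the scatter), which shows that a small group at this place does not by itself keep the number low. Nothing available here accounts for this behaviour of methoxy.

The compounds shown leave open whether ethyl or a longer chain on that carbonyl carbon would stay with the low numbers of compound 1 and compound 2. As far as these compounds go, it also remains open where an amine such as dimethylamino would fall at this place.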